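The compounds below may be only part of what the source reports. "The series", "measured", "known", "first", "only" and "open" are said of these compounds alone.

Of the compounds shown here, three sharing one core have been measured in a functional assay on HeLa cells (Homo sapiens) for inhibition, read by sulforhodamine B assay; on this read-out higher numbers stand for weaker inhibition and lower numbers for stronger inhibition. There, compound 1 `O=C1C=C(Nc2cccc(F)c2)C(=O)c2c1nc1n2[C@H]2OC[C@@H](O)[C@H]2OC1` gives 6440 nM, compound 2 `COc1ccc(NC2=CC(=O)c3nc4n(c3C2=O)[C@H]2OC[C@@H](O)[C@H]2OC4)cc1` gives 4780 nM, and compound 3 `O=C1C=C(Nc2ccccc2)C(=O)c2c1nc1n2[C@H]2OC[C@@H](O)[C@H]2OC1` gives 5620 nM. Compound 3 therefore stands within the scatter of both others, and the three cannot be ranked on these numbers. Compound 4 `O=C1C=C(N2CCCCC2)C(=O)c2c1nc1n2[C@H]2OC[C@@H](O)[C@H]2OC1` differs from compound 3 by piperidin-1-yl in place of anilino on a double-bonded ring carbon. The measured steps that bear on this change only alter the aromatic ring on the amine nitrogen: a 1.1-fold lower number from compound 1 to compound 3 (0.06 log units; within the scatter), a 1.2-fold higher number from compound 2 to compound 3 (0.07 log units; within the scatter) and a 1.3-fold lower number from compound 1 to compound 2 (0.13 log units; within the scatter) all stay within the scatter. Every measured compound keeps that aromatic ring, so the data hold no direct measure of replacing it, and the uncertainty is wide. With no measured step beyond the scatter, none is expected in this assay here, and no direction can be favoured. The estimated change is small: a 1.1-fold lower number from compound 3 to compound 4 (0.05 log units; within the scatter). For compound 4 the expected value is 5000 nM, with an estimated range from 1500 nM to 16000 nM.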

Compound 4, half-maximal inhibitory concentration: > 16000 nM
Compound 4 gave a limit, no number; the forecaster's own chance of this, stated with the estimate: 10%; middle value at least 3.2-fold (0.50 log units) from the limit.
By their numbers in this assay, from the lowest: compounds 2, 3 and 1 (each within the scatter of the next). At a limit, above all of these: compound 4.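

In this assay compound 4 gives a limit and not a number: the limit of > 16000 nM in this assay, at which 1 of the 4 values shown sits.

Changes on the aromatic ring stayed within the scatter, but replacing the whole amine substituent at this double-bonded ring carbon does not: piperidin-1-yl gives an at least 2.8-fold higher number from compound 3 to compound 4 (0.45 log units; beyond the scatter), along with an at least 3.3-fold higher number from compound 2 to compound 4 (0.52 log units; beyond the scatter) and an at least 2.4-fold higher number from compound 1 to compound 4 (0.39 log units; beyond the scatter). This position therefore responds to the kind of group attached, and all three steps point to weaker inhibition.

From the compounds shown here alone, since compound 4 gives only a limit, the full size of these steps stays open. The change also removes both the aromatic ring and the hydrogen-bond donor of anilino, so the compounds shown leave open which of these matters; cyclohexylamino would keep the donor without the aromatic ring, and N-methylanilino the aromatic ring without the donor.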